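The compounds below may be only part of what the source reports. "The series", "measured", "known", "first", "only" and "open" are said of these compounds alone.

Measured compounds:
compound 1 `O=C1CCC(N2C(=O)c3cccc(Nc4ccccn4)c3C2=O)C(=O)N1` — 1%
compound 2 `CCCc1ccc(Nc2cccc3c2C(=O)N(C2CCC(=O)NC2=O)C3=O)cc1` — 23%
compound 3 `CC(C)(C)c1ccc(Nc2ccc3c(c2)C(=O)N(C2CCC(=O)NC2=O)C3=O)cc1` — 17%

In an assay on FRT-Jurkat cells for inhibition of nuclear factor NF-kappa-B complex (Homo sapiens), read by flow cytometry, with a stated time of 24 h, tested at 10 uM (on this read-out lower numbers stand for less inhibition and higher numbers for more inhibition at the one concentration tested (going by the name of the read-out)), compound 2 gives the highest of the three numbers. Its gap to compound 3 is within the scatter, so the two cannot be ordered; its gap to compound 1 is beyond the scatter. Within the data shown here, the one step measured in one place is a number 22 percentage points higher from compound 1 to compound 2 (beyond the scatter), a modest rise when 4-propylphenyl replaces pyridin-2-yl on the nitrogen on the aromatic ring.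

Compound 4 `O=C1CCC(N2C(=O)c3cccc(Nc4ccc(O)cc4)c3C2=O)C(=O)N1` has not yet been measured in this assay. It differs from compound 2 by hydroxy in place of propyl on an aromatic carbon. The change sits on an aromatic carbon of a six-membered aromatic ring of carbon only, para to a large group, and cut one bond further out reads 4-propylphenyl to 4-hydroxyphenyl.

No measured step bears on this exchange: the single step shown compares two different rings on the nitrogen, not a change of the group on the phenyl ring. Because the gain in a number 22 percentage points higher from compound 1 to compound 2 (beyond the scatter) came with the propyl-bearing ring, removing propyl is expected to give up part of it, and compound 4 is expected to show a step of a number 13 percentage points lower from compound 2 to compound 4 (beyond the scatter). For compound 4 the estimated value is 10%, with a range from 0% to 25%.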

Compound 4, a percentage reported as inhibition, at one concentration (the size of the read-out at that concentration, not a potency): 4%
Compound 4: middle estimate off by 6 percentage points, on the high side; the range from low to high includes it.
By their numbers in this assay, from the lowest: compounds 1 and 4 (each within the scatter of the next); then compounds 3 and 2 (each within the scatter of the next).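

In this assay the group carried on the phenyl ring proves to matter on its own: with the rest of the molecule unchanged, hydroxy in place of propyl gives a number 19 percentage points lower from compound 2 to compound 4 (beyond the scatter) at this place on the six-membered aromatic ring of carbon only, para to a large group. The comparison with the pyridin-2-yl ring gives a number 3 percentage points higher from compound 1 to compound 4 (within the scatter) and so shows that a phenyl ring on the nitrogen does not by itself carry the earlier rise, since the 4-hydroxyphenyl and pyridin-2-yl compounds cannot be told apart in this read-out. Nothing at hand accounts for the difference between propyl and hydroxy at this place.

With only propyl and hydroxy shown on this phenyl ring, it remains open whether a longer chain, a methoxy group, an amine or a carboxylic acid would read like propyl, like hydroxy or like neither. On these data alone, all the readings also come from a single concentration, so the compounds' potencies and the shape of any concentration response remain open.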